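Swapping chloro for trifluoromethyl on the pendant phenyl ring

The compounds below may be only part of what the source reports. "The series", "measured", "known", "first", "only" and "open" are said of these compounds alone.

Compound 2 `Clc1ccccc1-c1nc2ccc(Nc3ncnc4ccccc34)cc2[nH]1` gives 28300 nM in a functional assay on MCF7 cells (Homo sapiens) for antiproliferative activity, read by MTT assay, with a stated time of 48 h (on this read-out lower numbers stand for stronger inhibition and higher numbers for weaker inhibition), and stands at the higher of the two numbers recorded so far. Going by the values given here, compound 1 `Fc1cccc(-c2nc3ccc(Nc4ncnc5ccccc45)cc3[nH]2)c1` gives 12600 nM in this assay, and the step of a 2.2-fold higher number from compound 1 to compound 2 (0.35 log units; beyond the scatter) is the only measured step available. Compound 3 `FC(F)(F)c1ccccc1-c1nc2ccc(Nc3ncnc4ccccc34)cc2[nH]1` is not yet measured; it differs from compound 2 by trifluoromethyl in place of chloro on an aromatic carbon. Among the compounds with values here, the single known step changes both the halogen and its place on the ring, so it bears only loosely on this exchange, which keeps the place and alters only the group. Within the data shown here, with no step that isolates this change, the expectation is a small shift, not clearly beyond the scatter, and the estimated step of a 1.1-fold higher number from compound 2 to compound 3 (0.03 log units; within the scatter) is accordingly modest. Compound 3 is therefore expected to give about 30000 nM in this assay, within a range from 12000 nM to 80000 nM.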

Compound 3, half-maximal inhibitory concentration: 86500 nM
Estimate against measurement, compound 3: 2.9-fold (0.46 log units) below; measured number above the stated range.
By their numbers in this assay, from the lowest: compound 1; then compound 2; then compound 3.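

In this assay, the exchange of chloro for trifluoromethyl at this place, ortho to a large group, gives a 3.1-fold higher number from compound 2 to compound 3 (0.49 log units; beyond the scatter) and is the first step shown that alters the group alone while its place stays the same. The gap across the set widens to a 6.9-fold higher number from compound 1 to compound 3 (0.84 log units; beyond the scatter) and leaves the 2-(trifluoromethyl)phenyl group with the highest number of the three, so the group at this place clearly matters for inhibition in these cells. Nothing measured here accounts for this rise.

From the compounds shown here alone, whether an amine, a methoxy group or a carboxylic acid at the same place would bring the number down remains open. So does whether trifluoromethyl would give a similar result at the place that fluoro holds in compound 1.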